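A further aromatic group on a silent core

The source may report more compounds than this note shows. Statements on the series, on what has been measured and on what is new or still open speak of the compounds shown alone.

Compound 3 `c1ccc2c(c1)CCC2c1ncc[nH]1` is the parent of this small set. In a functional assay on CHO cells for agonist activity at Alpha-1B adrenergic receptor (Homo sapiens), read by FLIPR and calcium flux (a higher number here means that more compound is needed for the effect, a lower number that less compound is needed), compound 3 gives only > 10000 nM, a limit of the assay rather than a number. Compound 1 `c1ccc(-c2cccc3c2CCC3c2ncc[nH]2)nc1`, carrying pyridin-2-yl on an aromatic carbon, gives > 10000 nM in this assay, again a limit. Compound 2 `Cn1ccc(-c2cccc3c2CCC3c2ncc[nH]2)n1`, with 1-methyl-1H-pyrazol-3-yl on that aromatic carbon, likewise gives > 10000 nM, a limit. Because (the limit of > 10000 nM in this assay, at which 3 of the 3 values shown sit), the steps a step that the two limits leave unreadable from compound 1 to compound 3 and a step that the two limits leave unreadable from compound 2 to compound 3 cannot be sized. Compound 4 `Cc1oncc1-c1cccc2c1CCC2c1ncc[nH]1` differs from compound 3 by 5-methyl-1,2-oxazol-4-yl in place of hydrogen on an aromatic carbon. Two aromatic substituents on that aromatic carbon have left the limit untouched, so compound 4 is expected to stay there as well, with an expected step that the limit leaves unreadable from compound 3 to compound 4 that carries little meaning. Compound 4 is estimated at 20000 nM, between 5000 nM and 100000 nM.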

Compound 4, half-maximal effective concentration: > 10000 nM
Compound 4: a limit, no number (the forecaster's own chance of this, stated with the estimate: 85%); the middle value lies beyond the limit too.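

No step among compound 1, compound 2, compound 3 and compound 4 can be read in this assay, because all of them sit at one limit: the limit of > 10000 nM in this assay, at which 4 of the 4 values shown sit.

The compounds shown leave open how far each lies beyond that limit, and so whether the three aromatic groups differ at all in this assay.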